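Lengthening a Chain on Compound 2: Expectation for Compound 3

This account rests on a few compounds, and the source may have more. Where it says the series, first, only, none or still open, it means among the compounds named here.

Of the compounds shown here, two have so far been measured in a functional assay on the whole organism for activation, with Mus musculus as the target; a higher number here means that more compound is needed for the effect, a lower number that less compound is needed. Compound 1 `CCCCOc1nc(N)c2[nH]c(=O)n(Cc3ccccc3)c2n1` gives 0.1 mg/kg in this assay. Compound 2 `CSc1nc(N)c2nc(O)n(Cc3ccccc3)c2n1` gives 0.1 mg/kg in this assay, level with compound 1 at the digits shown; the two values lie within the scatter of each other, so nothing separates them. Compound 3 `CCCCCSc1nc(N)c2nc(O)n(Cc3ccccc3)c2n1` has not yet been measured. It differs from compound 2 by butyl in place of hydrogen on a saturated chain carbon bound to a sulfur. Within the data shown here, no step between measured compounds is available, so the size of this change cannot be read off. Compound 1 and compound 2 carry chains of different length and still give the same value, so a small step in this assay, toward a higher dose or none beyond the scatter, is expected. For compound 3 the expected value in this assay is 0.2 mg/kg, between 0.05 mg/kg and 1 mg/kg. The expected step of a 2.0-fold higher number from compound 2 to compound 3 (0.30 log units; within the scatter) is estimated to be modest.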

Compound 3, minimum effective dose: 1 mg/kg
Compound 3: the middle estimate sits 5.0-fold (0.70 log units) below what was measured; low and high end bracket the measured number.
By their numbers in this assay, from the lowest: compounds 1 and 2 (each within the scatter of the next); then compound 3.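

In this assay, the saturated chain carbon bound to the sulfur proves to be a place where a change counts: butyl in place of hydrogen, which turns methylsulfanyl into pentylsulfanyl, gives a 10-fold higher number from compound 2 to compound 3 (1.00 log units; beyond the scatter). Among these compounds, the earlier compounds offered no step at this place, so this is the first direct reading of chain length on the sulfur, and here the longer chain calls for a higher dose. No measurement is available that accounts for this rise.

With only methylsulfanyl and pentylsulfanyl shown, it remains open how ethylsulfanyl or propylsulfanyl would fall and whether the dose climbs gradually or abruptly with length. From the compounds shown here alone, it is also open whether an amine or a carboxylic acid at the end of the pentyl chain would alter the step.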